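The source may report more compounds than this note shows. Statements on the series, on what has been measured and on what is new or still open speak of the compounds shown alone.

Measured compounds:
- compound 1 `CN(Cc1ccc(OCCCNC(=N)N)cc1)c1nc2ccc(Oc3ccc(O)cc3)cc2s1` in an assay on cells for inhibition of Voltage-dependent T-type calcium channel subunit alpha-1H (Homo sapiens), read by FLIPR and calcium flux, with stated times of 600 s and 300 s (a lower number here means a stronger inhibitor, a higher number a weaker inhibitor), gives 332000 nM
- compound 2 `CN(Cc1ccc(OCCCNC(=N)N)cc1)c1nc2ccc(Oc3ccccc3)cc2s1` in this assay gives 498000 nM

Compound 2 stands at the highest of the two numbers; its nearest neighbour is compound 1, from which it is separated by a 1.5-fold higher number from compound 1 to compound 2 (0.18 log units; within the scatter), a change of hydrogen in place of hydroxy on an aromatic carbon. Both numbers are very high, so neither compound is a strong inhibitor in this assay.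

Compound 3 `CN(Cc1ccc(OCCCNC(=N)N)cc1)c1nc2ccc(Oc3ccc(C#N)cc3)cc2s1` differs from compound 2 by cyano in place of hydrogen on an aromatic carbon. Among the measured compounds shown here, the only measured step that bears on this position is the one from compound 1 to compound 2, which lay within the scatter. For the measured compounds named here, there is no measured example of a cyano group at this position, so the expectation rests on the one step alone, and that step gives no sign that substitution on this ring moves the number beyond the scatter.

Compound 3 is therefore expected to stay close to compound 2, with an estimated step of a 1.1-fold lower number from compound 2 to compound 3 (0.04 log units; within the scatter). The estimate for compound 3 is 450000 nM, with a range from 180000 nM to 1100000 nM.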

Compound 3, half-maximal inhibitory concentration: 153000 nM
Estimate against measurement, compound 3: 2.9-fold (0.47 log units) above; measured number outside the range, below it.
By their numbers in this assay, from the lowest: compound 3; then compounds 1 and 2 (each within the scatter of the next).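

In this assay, the change from phenoxy to 4-cyanophenoxy gives the first step at this position that lies beyond the scatter (a 3.3-fold lower number from compound 2 to compound 3 (0.51 log units; beyond the scatter)), so this aromatic carbon, para to a large group, does respond to substitution, which the step between hydroxy and hydrogen alone had not shown. The two groups that enter here also differ from each other, since exchanging hydroxy for cyano at the same carbon gives a second step beyond the scatter (a 2.2-fold lower number from compound 1 to compound 3 (0.34 log units; beyond the scatter)), although both steps are modest and all three numbers remain very high. Nothing measured here accounts for the lower number of compound 3, and no supporting evidence bears on this result.

The compounds shown do not tell whether the lower number is particular to cyano or would also appear with another group at this carbon, such as an amine, a carboxylic acid or a methoxy group. Nor do they tell whether the cyano step would hold with a shorter or longer chain in place of the one that all three compounds share.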